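The source may report more compounds than this note shows. Statements on the series, on what has been measured and on what is new or still open speak of the compounds shown alone.

Of the compounds shown here, three built on one shared core have been tested in a functional assay on A549 cells (Homo sapiens) for cytotoxicity, read by MTT assay, with a stated time of 72 h; a higher number here means a weaker inhibitor, a lower number a stronger inhibitor. Compound 1 `CC1(C)OCC(Cn2cc(Cn3c4c(c5ccccc53)C(=O)c3c[n+]([O-])c5ccccc5c3C4=O)nn2)O1` gives 80 nM, and compound 3 `CC1(C)O[C@@H](CO)[C@H](Cn2cc(Cn3c4c(c5ccccc53)C(=O)c3c[n+]([O-])c5ccccc5c3C4=O)nn2)O1` gives 370 nM. Compound 2 `O=C1c2c[n+]([O-])c3ccccc3c2C(=O)c2c1c1ccccc1n2Cc1cn(CC(O)CO)nn1` gives 880 nM, the highest number of the three, which makes it the weakest inhibitor in this small set: the step of a 2.4-fold lower number from compound 2 to compound 3 (0.38 log units; beyond the scatter) places compound 3 nearest to it, and the step of an 11-fold higher number from compound 1 to compound 2 (1.04 log units; beyond the scatter) places compound 1 furthest away. The step of a 4.6-fold higher number from compound 1 to compound 3 (0.67 log units; beyond the scatter) completes the picture.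

Compound 4 `CN1CCN(CCCCCCn2c3c(c4ccccc42)C(=O)c2c[n+]([O-])c4ccccc4c2C3=O)CC1` has not yet been measured. Its difference from compound 2 is this: 5-(4-methylpiperazin-1-yl)pentyl in place of 1-(2,3-dihydroxypropyl)-1H-1,2,3-triazol-4-yl on a saturated chain carbon bound to an aromatic nitrogen. None of the three measured steps bears directly on this change. Each of them only exchanges one dioxolane or diol group for another while the triazole ring stays in place; none removes the triazole ring or brings in a piperazine ring. The change to compound 4 is therefore larger in kind than anything measured here, and its direction cannot be read from the measured steps. The estimate below rests on the general standing of compound 2 as the weakest of the three. For compound 4 the expected step is a 3.5-fold lower number from compound 2 to compound 4 (0.55 log units; beyond the scatter), a lower number. Compound 4 is estimated at 250 nM, within a range from 40 nM to 1500 nM.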

Compound 4, half-maximal inhibitory concentration: 330 nM
Compound 4: the middle estimate sits 1.3-fold (0.12 log units) below what was measured; measured number inside the range.
By their numbers in this assay, from the lowest: compound 1; then compounds 4 and 3 (each within the scatter of the next); then compound 2.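

At the saturated chain carbon bound to an aromatic nitrogen, replacing 1-(2,3-dihydroxypropyl)-1H-1,2,3-triazol-4-yl with 5-(4-methylpiperazin-1-yl)pentyl in this assay gives a 2.7-fold lower number from compound 2 to compound 4 (0.43 log units; beyond the scatter). The three steps among compounds 1, 2 and 3 only exchange a dioxolane or diol group while the triazole ring stays in place, whereas this step shows that the number can fall with the triazole ring and both hydroxyl groups gone and a piperazine ring present. Because several features change at once here, including the ring, the chain and the counts of hydrogen-bond donors and acceptors, this one step cannot assign the gain to any one of them, and no measurement is available to explain it.

The compounds shown leave open whether the piperazine ring, the pentyl chain or the loss of the triazole ring matters most, a question that a triazole ring carrying a 4-methylpiperazine group could help to separate. They also leave open how the number would respond to a morpholine ring or a dimethylamino group at the end of the chain, or to a shorter or longer chain.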